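A few compounds are considered here, and "the series" means these few. Any claim that something is new, unique, unknown or untested is made for them only; others in the source may bear on it.

Series notes. The shared core of compound 1 `CCCSc1nc(N/N=C/c2cccc(Cl)c2)c2nnn(Cc3ccccc3)c2n1` carries a 3-chlorophenyl on a carbon with a double bond to nitrogen. In a functional assay on ECa-109 cells (Homo sapiens) for antiproliferative activity, read by MTT assay, with a stated time of 72 h (a higher number here means a weaker inhibitor, a lower number a stronger inhibitor), compound 1 reaches only a limit of the assay, > 64000 nM (the limit of > 64000 nM in this assay, at which 1 of the 3 values shown sits). Compound 2 `CCCSc1nc(N/N=C(\C)c2ccccc2O)c2nnn(Cc3ccccc3)c2n1` gives 11100 nM in this assay, and compound 3 `CCCSc1nc(N/N=C(\C)c2ccccc2)c2nnn(Cc3ccccc3)c2n1` gives 32200 nM. Both exchanges of the aryl group away from compound 1 give lower numbers: an at least 5.7-fold lower number from compound 1 to compound 2 (0.76 log units; beyond the scatter) and an at least 1.9-fold lower number from compound 1 to compound 3 (0.29 log units; that floor lies within the scatter); between those two, a 2.9-fold higher number from compound 2 to compound 3 (0.46 log units; beyond the scatter). Compound 4 `CCCSc1nc(N/N=C/c2ccc([N+](=O)[O-])cc2)c2nnn(Cc3ccccc3)c2n1` differs from compound 1 by 4-nitrophenyl in place of 3-chlorophenyl on a carbon with a double bond to nitrogen. The aryl exchanges already measured bear on this step, though none carries a nitro group and compound 1 stands at a limit, so the direction is open. Compound 4 is expected near 40000 nM, between 10000 nM and 130000 nM. The expected step is an at least 1.6-fold lower number from compound 1 to compound 4 (0.20 log units; that floor lies within the scatter).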

Compound 4, half-maximal inhibitory concentration: 6640 nM
Compound 4: middle estimate off by 6.0-fold (0.78 log units), on the high side, outside the stated range (below it).
By their numbers in this assay, from the lowest: compounds 4 and 2 (each within the scatter of the next); then compound 3. At a limit, above all of these: compound 1.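

In this assay, 4-nitrophenyl in place of 3-chlorophenyl gives an at least 9.6-fold lower number from compound 1 to compound 4 (0.98 log units; beyond the scatter). Unlike the earlier exchanges away from compound 1, this one adds no methyl on the carbon with a double bond to nitrogen, so an aryl exchange alone moves the number beyond the scatter. The step is only a floor, as compound 1 stands at a limit: the limit of > 64000 nM in this assay, at which 1 of the 4 values shown sits.

The compounds shown do not separate the effect of the nitro group from that of its ring position, which 4-chlorophenyl and 3-nitrophenyl would address. From the compounds shown here alone, how 4-aminophenyl or 4-carboxyphenyl would read here also remains open.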